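Swapping a chloroacetyl urea for an acrylamide

A few compounds are considered here, and "the series" means these few. Any claim that something is new, unique, unknown or untested is made for them only; others in the source may bear on it.

Compound 2 `CC(C)(C)c1ccc(CNC(=O)NC(=O)CCl)cc1` gives the lowest number among three measured compounds in a functional assay on M21 cells (Homo sapiens) for antiproliferative activity, with a stated time of 48 h (a lower number here means a stronger inhibitor, a higher number a weaker inhibitor), namely 2400 nM. The next nearest is compound 3 `O=C(CCCl)Nc1ccc(I)cc1`, which in this assay gives 20000 nM, and the furthest is compound 1 `CCCCCc1cccc(NC(=O)NCCCCl)c1`, which gives 24000 nM; both of those gaps lie beyond the usual scatter. Compound 4 `C=CC(=O)NCc1ccc(C(C)(C)C)cc1` has not been measured. It differs from compound 2 by vinyl in place of ((chloromethyl)carbonyl)amino on a carbonyl carbon. For the measured compounds named here, no measured pair shows this exact change, so the size of the step is uncertain; a move toward weaker inhibition, beyond the scatter, is expected. Compound 4 is therefore expected to give about 6000 nM, likely between 1500 nM and 25000 nM, a step of a 2.5-fold higher number from compound 2 to compound 4 (0.40 log units; beyond the scatter) from compound 2.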

Compound 4, half-maximal inhibitory concentration: 72000 nM
Estimate against measurement, compound 4: 12-fold (1.08 log units) below; the measured number lies above the stated range.
By their numbers in this assay, from the lowest: compound 2; then compounds 3 and 1 (each within the scatter of the next); then compound 4.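

In this assay, putting vinyl in place of ((chloromethyl)carbonyl)amino on the carbonyl carbon brings a large loss of inhibition, a 30-fold higher number from compound 2 to compound 4 (1.48 log units; beyond the scatter), so activity depends strongly on what sits at this position. For the compounds shown here, the earlier compounds offered no pair differing in one place, so this is the first step that can be read. Nothing available accounts for the size of this step.

Going by these compounds, the change removes the chlorine and the nitrogen together, so which of them matters remains open. A chloromethyl group alone on that carbonyl carbon, or an amine or a longer chain there, could help to separate these parts.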